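Adding 1-carbamoylpentyl to Compound 2

A few compounds are considered here, and "the series" means these few. Any claim that something is new, unique, unknown or untested is made for them only; others in the source may bear on it.

In a physicochemical assay for lipophilicity, read by HPLC, at pH 7.5 (on this read-out lower numbers stand for lower lipophilicity and higher numbers for higher lipophilicity), compound 2 (`CCOc1ccccc1-c1ccc(-c2nc3cnccc3c(N)c2C#N)cc1`) gives 3 as the lower of the two numbers available, and compound 1 (`CCOc1ccccc1-c1ccc(-c2nc3cnccc3c(N[C@H](CC)C(=O)N(C)C)c2C#N)cc1`) gives 3.7 as the higher. Compound 3 (`CCCCC(Nc1c(C#N)c(-c2ccc(-c3ccccc3OCC)cc2)nc2cnccc12)C(N)=O`) has not yet been measured. It carries 1-carbamoylpentyl in place of hydrogen on a nitrogen on an aromatic ring. Among the compounds with values here, in compound 1 that place holds 1-(dimethylcarbamoyl)propyl, and only one measured step bears on the change: a number 0.70 log units lower from compound 1 to compound 2 (beyond the scatter) on going to hydrogen. Read in reverse, this modest step points upward, although the two entering groups differ and no measurement compares them directly. A rise of similar size, beyond the scatter, is therefore expected, estimated as a number 0.70 log units higher from compound 2 to compound 3 (beyond the scatter) in this assay on this reading. For this assay the expected value of compound 3 is 3.7 (estimated range 3.2 to 4.2).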

Compound 3, distribution coefficient: 3.6
Estimate against measurement, compound 3: 0.10 log units above; measured number inside the range.
By their numbers in this assay, from the lowest: compound 2; then compounds 3 and 1 (each within the scatter of the next).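

In this assay, 1-carbamoylpentyl on the nitrogen gives a number 0.60 log units higher from compound 2 to compound 3 (beyond the scatter), so a second group at this place, and not only 1-(dimethylcarbamoyl)propyl, stands apart from hydrogen. Exchanging one group for the other gives a number 0.10 log units lower from compound 1 to compound 3 (within the scatter), so this read-out does not separate the two, although their names show that they differ in both the chain and the amide. Nothing available accounts for this result.

What the compounds shown leave open is whether the amide matters at all, since neither a plain pentyl group nor a carboxylic acid or an amine in its place appears among them. Also open, on these data alone, is what 1-(dimethylcarbamoyl)pentyl would read, which would set the longer chain and the dimethyl amide together on this nitrogen.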